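The compounds below may be only part of what the source reports. "The series", "measured", "known", "first", "only" and "open" are said of these compounds alone.

Measured in an assay on isolated protein for inhibition of Myeloperoxidase (Homo sapiens), with a stated time of 5 min (a lower number here means a stronger inhibitor, a higher number a weaker inhibitor), so far:

- compound 1 `O=C(NO)c1ccc(Cc2ccccc2)cc1O` gives 25 nM
- compound 2 `NCCCCc1c[nH]c2ccc(F)cc12` gives 8 nM
- compound 3 `Cc1nc(N=C(N)N)nc2ccc(F)cc12` gives 145 nM

Compound 3 stands at the highest of the three numbers in this assay. Its nearest neighbour is compound 1, whose number is lower by a gap beyond the usual scatter; compound 2 lies furthest, lower by a larger gap, also beyond the scatter. Within the data shown here, the three measured compounds do not share a core, and no pair among them differs in one place only, so no single-point step within the measured set is available to calibrate the next change.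

The next compound, compound 4 `Cc1nc(N=C(N)N)nc2ccc(Cl)cc12`, is built from compound 3 by one change: chloro in place of fluoro on an aromatic carbon. The substituent keeps its place on the carbon-only six-membered aromatic ring of the fused system and only its halogen identity changes. Among the measured compounds shown here, with no comparable step among the measured compounds, the expectation for this kind of swap is a step of small size, not beyond the scatter, in either direction.

On that basis compound 4 is expected to give 120 nM in this assay, with a range from 50 nM to 300 nM. The expected step from compound 3 to compound 4 is a 1.2-fold lower number from compound 3 to compound 4 (0.08 log units; within the scatter).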

Compound 4, half-maximal inhibitory concentration: 630 nM
The estimate for compound 4 lay 5.3-fold (0.72 log units) below the measured number; measured number outside the range, above it.
By their numbers in this assay, from the lowest: compound 2; then compound 1; then compound 3; then compound 4.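

In this assay the halogen on the carbon-only six-membered aromatic ring is not an interchangeable detail: the swap of fluoro for chloro gives a 4.3-fold higher number from compound 3 to compound 4 (0.64 log units; beyond the scatter), a step beyond the scatter and the first single-point comparison available in this series. The place on the ring stays the same, and the heavy-atom, donor, acceptor and net-charge counts match on both sides, so this step belongs to the identity of the halogen alone, with fluoro on the side of the lower number in this pair. Nothing measured here speaks to the reason for the step.

Still open, as far as these compounds go, is how a bromo, a methoxy or a plain hydrogen at this same place would compare with the fluoro and chloro pair, and whether the numbers would follow any order across such groups. This is one step on one core, so it also leaves open whether chloro in place of fluoro would move the number in the same direction on the core of compound 2, which carries its own fluoro.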